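Selenium gives way to tellurium on a long chain

The compounds below may be only part of what the source reports. "The series", "measured", "known", "first", "only" and "open" are said of these compounds alone.

In a functional assay on HCT-116 cells (Homo sapiens) for cytotoxicity, read by MTT assay, with a stated time of 24 h (a higher number here means a weaker inhibitor, a lower number a stronger inhibitor), compound 1 `O=S(=O)(O)OCCCCCCCCCC[Te]c1ccccc1` gives 7470 nM. Compound 2 `O=S(=O)(O)OCCCCCCCCCCCC[Se]c1ccccc1` gives > 100000 nM, which is a limit of the assay and not a number. Compound 3 `O=S(=O)(O)OCCCCCCCCCCC[Te]c1ccccc1` differs from compound 2 in one place: a group of 7 heavy atoms (6 carbon, 1 tellurium; one six-membered aromatic ring of carbon only) in place of a group of 8 heavy atoms (7 carbon, 1 selenium; one six-membered aromatic ring of carbon only), on a saturated chain carbon, ten or more bonds along the chain from an oxygen. Among the compounds with values here, no measured pair isolates this change. The best guide is compound 1 at 7470 nM, which also carries tellurium, so stronger inhibition is expected, well beyond the scatter. The estimated step runs an at least 10-fold lower number from compound 2 to compound 3 (1.00 log units; beyond the scatter). For compound 3 the expected value is 10000 nM, with an estimated range of 3000 nM to 40000 nM.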

Compound 3, half-maximal inhibitory concentration: 9730 nM
Compound 3: the middle estimate sits 1.0-fold (0.01 log units) above what was measured; measured number inside the range.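

In this assay this position responds strongly to the exchange of the selenium group for the tellurium group, with an at least 10-fold lower number from compound 2 to compound 3 (1.01 log units; beyond the scatter). Within the data shown here, that step starts from a limit of the assay and not a number, the one held by compound 2: the limit of > 100000 nM in this assay, at which 1 of the 3 values shown sits. Among the tellurium compounds, the data show a 1.3-fold higher number from compound 1 to compound 3 (0.11 log units; within the scatter), so (sulfooxy)methyl in place of sulfooxy does not separate the two.

Still open, going by these compounds, is how much of the large step belongs to tellurium itself and how much to the chain. Also open, on these data alone, is whether a carboxylic acid in place of sulfooxy would keep the same level.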